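A few compounds are considered here, and "the series" means these few. Any claim that something is new, unique, unknown or untested is made for them only; others in the source may bear on it.

Measured so far:
Compound 1 `CC(CC(=O)/N=C(\N)NCCCc1cccnc1)c1ccccc1` gives 5.27 in a functional assay on Sf9 cells for antagonist activity at histamine H2 receptor (Homo sapiens), with stated times of 2 min and 20 min; on this read-out higher numbers stand for higher potency (the scale is a negative logarithm) and lower numbers for lower potency.
Compound 2 `N/C(=N\C(=O)CC(c1ccccc1)c1ccccc1)NCCCc1cccnc1` gives 6.14 in this assay.
Compound 3 `CC(CC(=O)/N=C(\N)NCCCc1ccncc1)c1ccccc1` gives 5.54 in this assay.

Compound 4 `N/C(=N\C(=O)CC(c1ccccc1)c1ccccc1)NCCCc1ccncc1` has not yet been measured. It is made from compound 3 by phenyl in place of methyl on a saturated chain carbon bound to an aromatic carbon and a saturated chain carbon. The same change separates compound 1 from compound 2, namely (phenyl in place of methyl on a saturated chain carbon bound to an aromatic carbon and a saturated chain carbon), and there it produced a number 0.87 log units higher from compound 1 to compound 2 (beyond the scatter). The two cores differ only in pyridin-4-yl in place of pyridin-3-yl on a saturated chain carbon, three bonds along the chain from an amine nitrogen, a change that brought a number 0.27 log units higher from compound 1 to compound 3 (within the scatter), so the core of compound 3 behaves much like that of compound 1. Because the earlier step, a number 0.87 log units higher from compound 1 to compound 2 (beyond the scatter), was clear and the place of the change is the same, a step of a number 0.81 log units higher from compound 3 to compound 4 (beyond the scatter) is expected for compound 4. On that basis compound 4 is estimated at 6.35 in this assay, with a likely range from 5.9 to 6.8.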

Compound 4, negative logarithm of the antagonist equilibrium constant: 6.14
The estimate for compound 4 lay 0.21 log units above the measured number; measured number inside the range.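

In this assay, phenyl in place of methyl carried over to the second core with a number 0.60 log units higher from compound 3 to compound 4 (beyond the scatter), and the two steps for this change agree: the same change on two cores in this assay, a number 0.87 log units higher (beyond the scatter) from compound 1 to compound 2 and a number 0.60 log units higher (beyond the scatter) from compound 3 to compound 4, 0.27 log units apart, within the scatter of two such steps. Pyridin-4-yl in place of pyridin-3-yl gave no change at the digits printed from compound 2 to compound 4 (within the scatter), and this change also reads alike on both cores: the same change on two cores in this assay, a number 0.27 log units higher (within the scatter) from compound 1 to compound 3 and no change at the digits printed (within the scatter) from compound 2 to compound 4, 0.27 log units apart, within the scatter of two such steps. Within these four compounds the two changes therefore act independently of each other, but that does not show that they would do so on any other core or explain what lies behind either step.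

Going by these compounds, what an amine or a carboxylic acid in place of phenyl on that saturated chain carbon would do stays open. So does the effect of a longer chain carrying the pyridin-4-yl.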